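The compounds below may be only part of what the source reports. "The series", "measured", "known", "first", "only" and "open" are said of these compounds alone.

Working notes on the series.

Three compounds have numbers in an assay on microsomes from liver for inhibition of 3-hydroxy-3-methylglutaryl-coenzyme A reductase (Rattus norvegicus); on this read-out lower numbers stand for stronger inhibition and higher numbers for weaker inhibition. Compound 1 `Cc1ccc(CNC(=O)c2nn(-c3ccc(F)cc3)c(OC[C@@H](O)C[C@@H](O)CC(=O)O)c2C(C)C)cc1` gives 15 nM. Compound 2 `COCc1cccc(CNC(=O)c2nn(-c3ccc(F)cc3)c(OC[C@@H](O)C[C@@H](O)CC(=O)O)c2C(C)C)c1` gives 31 nM, and compound 3 `CC(C)c1c(C(=O)NCc2cccc(Cl)c2)nn(-c2ccc(F)cc2)c1OC[C@@H](O)C[C@@H](O)CC(=O)O` gives 5.4 nM. Compound 1 therefore stands second highest of the three: the step of a 2.1-fold higher number from compound 1 to compound 2 (0.32 log units; beyond the scatter) is modest, and the step of a 2.8-fold lower number from compound 1 to compound 3 (0.44 log units; beyond the scatter) is also modest, so compound 1 sits between the other two, each of them beyond the scatter.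

Compound 4 `CC(C)c1c(C(=O)N(C)Cc2ccc(F)c(F)c2)nn(-c2ccc(F)cc2)c1OC[C@@H](O)C[C@@H](O)CC(=O)O` has not been measured in this assay. It differs from compound 1 in one place: (3,4-difluorobenzyl)(methyl)amino in place of (4-methylbenzyl)amino on a carbonyl carbon. Two parts of this change can be separated. The aryl substitution has precedents: the step of a 2.8-fold lower number from compound 1 to compound 3 (0.44 log units; beyond the scatter) shows a halogen on the ring lowering the number, while the step of a 5.7-fold lower number from compound 2 to compound 3 (0.76 log units; beyond the scatter) points the same way. Among the compounds with values here, the methyl on the amide-type nitrogen, with loss of the hydrogen-bond donor, has no precedent among the measured compounds, so its effect is unknown.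

The ring change alone would suggest a somewhat lower number; the unprecedented change on the nitrogen widens the uncertainty in both directions. On balance, compound 4 is estimated at 12 nM, within 3 nM to 60 nM, which means an expected step of a 1.3-fold lower number from compound 1 to compound 4 (0.10 log units; within the scatter).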

Compound 4, half-maximal inhibitory concentration: 5.7 nM
Compound 4: the middle estimate sits 2.1-fold (0.32 log units) above what was measured, within the range that was stated.
By their numbers in this assay, from the lowest: compounds 3 and 4 (each within the scatter of the next); then compound 1; then compound 2.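

In this assay, within the data shown here, the replacement of (4-methylbenzyl)amino by (3,4-difluorobenzyl)(methyl)amino on the carbonyl carbon gives a 2.6-fold lower number from compound 1 to compound 4 (0.42 log units; beyond the scatter) and so shows for the first time that this position can carry a tertiary amide, without the amide hydrogen, and still give a low number. Set against the best earlier group, the change gives a 1.1-fold higher number from compound 3 to compound 4 (0.02 log units; within the scatter) so compound 4 and compound 3 cannot be told apart, even though they differ in ring halogens and in the methyl on the nitrogen. Against the methoxymethyl-bearing group the change gives a 5.4-fold lower number from compound 2 to compound 4 (0.74 log units; beyond the scatter) and compound 2 remains the only one of the four whose number stands apart from both halogen-bearing compounds by a step of this size.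

The methyl and the two fluorines enter together, so the compounds shown cannot assign the step to either one, and (3,4-difluorobenzyl)amino, (3-chlorobenzyl)(methyl)amino or a longer chain such as ethyl on the nitrogen would be needed to separate them. Nothing at hand bears on the reason for this result.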